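Solubility across the heteroaryl swaps, compound 3 to compound 4

The source may hold more compounds than are shown below. What is called first, only, known or untested is meant among the compounds shown, and "the series" means these compounds.

In a physicochemical assay for solubility, in phosphate buffer, with a stated time of 18 h (on this read-out lower numbers stand for lower solubility and higher numbers for higher solubility), compound 1 `CC(C)(C)c1nc(-c2ccncc2)c2c(N)c(C#N)c(N)nc2n1` gives 44000 nM, compound 2 `CC(C)(C)c1nc(-c2cnccn2)c2c(N)c(C#N)c(N)nc2n1` gives 86000 nM and compound 3 `CC(C)(C)c1nc(-c2ccn[nH]2)c2c(N)c(C#N)c(N)nc2n1` gives 13500 nM, the lowest of the three. Compound 4 `CC(C)(C)c1nc(-c2ncn[nH]2)c2c(N)c(C#N)c(N)nc2n1` carries 1H-1,2,4-triazol-5-yl in place of 1H-pyrazol-5-yl on an aromatic carbon. Measured swaps into the pyrazolyl group are modest: a 3.3-fold lower number from compound 1 to compound 3 (0.51 log units; beyond the scatter) and a 6.4-fold lower number from compound 2 to compound 3 (0.80 log units; beyond the scatter). Among the compounds with values here, none of the measured steps exchanges one five-membered ring for another, so the guide is weak. The nearest hint is compound 2, with a 2.0-fold higher number from compound 1 to compound 2 (0.29 log units; within the scatter), which stays within the scatter. The expected change is a 1.5-fold higher number from compound 3 to compound 4 (0.17 log units; within the scatter), a slight rise not beyond the scatter. For compound 4 the estimate in this assay is 20000 nM, with an expected range of 7000 nM to 60000 nM.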

Compound 4, solubility: 64500 nM
The estimate for compound 4 lay 3.2-fold (0.51 log units) below the measured number; the measured number lies above the stated range.
By their numbers in this assay, from the lowest: compound 3; then compounds 1, 4 and 2 (each within the scatter of the next).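

In this assay this position now has a step between two five-membered rings, and it is beyond the scatter: a 4.8-fold higher number from compound 3 to compound 4 (0.68 log units; beyond the scatter) follows from 1H-1,2,4-triazol-5-yl in place of 1H-pyrazol-5-yl. The low number of compound 3 therefore does not extend to both five-membered rings, since a 1.3-fold lower number from compound 2 to compound 4 (0.12 log units; within the scatter) and a 1.5-fold higher number from compound 1 to compound 4 (0.17 log units; within the scatter) both lie within the scatter. No supporting data here explain the step.

Open, from the compounds shown here alone, is whether a tetrazolyl ring at this place would follow compound 4 or compound 3, and whether an amine on the triazolyl ring would alter the number.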